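The compounds below may be only part of what the source reports. "The series", "measured", "known", "first", "only" and "open" are said of these compounds alone.

Compound 3 `COc1cc(-c2ccnc3cc(-c4ccc5c(ccn5C)c4)nn23)cc(OC)c1OC` gives 39 nM in a functional assay on HCT-116 cells (Homo sapiens) for inhibition, read by CCK-8 assay, with a stated time of 48 h; on this read-out lower numbers stand for stronger inhibition and higher numbers for weaker inhibition. Among the three measured compounds it holds the second highest number, nearest to compound 2 `COc1cc(-c2ccnc3cc(-c4c[nH]c5ccccc45)nn23)cc(OC)c1OC`, which gives 35 nM, and furthest from compound 1 `COc1cc(-c2ccnc3cc(-c4ccc(C)cc4)nn23)cc(OC)c1OC`, which gives 48 nM; both distances lie within the scatter, so no order among the three can be read from them. Compound 4 `COc1cc(-c2ccnc3cc(-c4cn(C)c5ccccc45)nn23)cc(OC)c1OC` is not yet measured. It differs from compound 3 in one place: 1-methyl-1H-indol-3-yl in place of 1-methyl-1H-indol-5-yl on an aromatic carbon, the two having the same atoms joined differently. The step that bears most on this is a 1.1-fold higher number from compound 2 to compound 3 (0.05 log units; within the scatter), since compound 2 already carries the indole attached through its three-position, and compound 4 carries the same attachment with the ring nitrogen methylated. The steps of a 1.4-fold lower number from compound 1 to compound 2 (0.14 log units; within the scatter) and a 1.2-fold lower number from compound 1 to compound 3 (0.09 log units; within the scatter) likewise stayed within the scatter. Compound 4 is therefore expected to show a 1.0-fold lower number from compound 3 to compound 4 (0.01 log units; within the scatter), no step beyond the scatter. Compound 4 is estimated at 38 nM, with a range from 18 nM to 80 nM.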

Compound 4, half-maximal inhibitory concentration: 762 nM
Compound 4: the middle estimate sits 20-fold (1.30 log units) below what was measured; the whole stated range lies below it.
By their numbers in this assay, from the lowest: compounds 2, 3 and 1 (each within the scatter of the next); then compound 4.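

In this assay, methyl in place of hydrogen on the aromatic nitrogen of the indol-3-yl group gives a 22-fold higher number from compound 2 to compound 4 (1.34 log units; beyond the scatter), so this single methyl separates two compounds at a position where the earlier changes all stayed within the scatter. The position also distinguishes two groups with the same atoms joined differently: 1-methyl-1H-indol-3-yl in place of 1-methyl-1H-indol-5-yl gives a 20-fold higher number from compound 3 to compound 4 (1.29 log units; beyond the scatter), and in place of 4-methylphenyl it gives a 16-fold higher number from compound 1 to compound 4 (1.20 log units; beyond the scatter). Nothing available explains this loss.

The compounds shown leave open whether an ethyl or acetyl group on the same indole nitrogen would follow compound 4 or compound 2. They also leave open how 1H-indol-5-yl, with hydrogen on its nitrogen, would compare with compound 3.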